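A larger group on the aromatic carbon of compound 2

The source may hold more compounds than are shown below. What is called first, only, known or untested is meant among the compounds shown, and "the series" means these compounds.

Compound 1 `COC(c1cc(Cl)c2c(c1Cl)C(=O)N(Cc1c(C)cc(C)[nH]c1=O)CC2)C1CCOCC1` (3.4; 3.5 (2 entries))
Compound 2 `Cc1cc(C)c(CN2CCc3c(Cl)cc([C@@H](C)CO)c(Cl)c3C2=O)c(=O)[nH]1` (2.5)

In a physicochemical assay for lipophilicity, at pH 7.4 (a higher number here means a more lipophilic compound, a lower number a more polar compound), compound 2 stands lower than compound 1, whose two entries agree closely (the several entries of compound 1 in this assay, 3.4; 3.5 (2 entries)). Within the data shown here, for compound 2 there is the single number 2.5 and one further entry without a single number.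

Compound 3 `Cc1cc(C)c(CN2CCc3c(Cl)cc([C@@H](CO)[C@H]4CCCO4)c(Cl)c3C2=O)c(=O)[nH]1` has not yet been measured. It differs from compound 2 in one place, on an aromatic carbon ortho to a chloro group, where the 1-(hydroxymethyl)ethyl group gives way to a larger group with a five-membered non-aromatic ring (a group of 8 heavy atoms (6 carbon, 2 oxygen; one five-membered non-aromatic ring with 1 hetero atom) in place of a group of 4 heavy atoms (3 carbon, 1 oxygen; no ring), on an aromatic carbon).

Among the measured compounds shown here, no measured pair of compounds isolates a change of this kind, so the expectation rests on a looser comparison. Compound 1, whose group also contains a ring, gives 3.4; 3.5 (2 entries) in this assay and marks the upper side of the numbers at hand. A moderate rise is therefore expected, and the estimated size of it is a number 0.30 log units higher from compound 2 to compound 3 (within the scatter) in this assay overall. For compound 3 the estimated value is 2.8 (expected range 2.4 to 3.2).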

Compound 3, distribution coefficient: 2.5
Estimate against measurement, compound 3: 0.30 log units above; the measured number falls inside the stated range.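

In this assay, replacing the 1-(hydroxymethyl)ethyl group on the aromatic carbon ortho to a chloro group with the larger group, which has a five-membered non-aromatic ring and a second defined stereocentre, shows no change at the digits printed from compound 2 to compound 3 (within the scatter). At this position, then, going from 4 heavy atoms without a ring to 8 heavy atoms with a ring, while the hydrogen-bond donor count stays at 1 and a hydrogen-bond acceptor is added, leaves the read-out of this assay unmoved. A ring in this group is therefore not enough on its own to bring a compound to the level of compound 1, whose group also holds a ring and whose repeated entries agree closely: the several entries of compound 1 in this assay, 3.4; 3.5 (2 entries)

The compounds shown do not separate whether the level of compound 1 goes with its methoxy group, which stands where compound 3 has a hydroxymethyl arm, or with its six-membered ring, since the two differ together. From the compounds shown here alone, how this position would respond to a group of another kind, such as an amine or a carboxylic acid, also remains open.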